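A few compounds are considered here, and "the series" means these few. Any claim that something is new, unique, unknown or untested is made for them only; others in the source may bear on it.

Measured compounds in this series:

- compound 1, `CN1CCN(c2ccc(Nc3ncc4nc(Nc5ccc(F)cc5)n([C@@H]5CCN(C(=O)CO)C5)c4n3)cc2)CC1`: 350 nM
- compound 2, `CN1CCN(c2ccc(Nc3ncc4nc(Nc5ccc(F)cc5)n([C@@H]5CCN(S(=O)(=O)C6CC6)C5)c4n3)cc2)CC1`: 2.5 nM
- compound 3, `CN1CCN(c2ccc(Nc3ncc4nc(Nc5ccc(F)cc5)n(CCNS(=O)(=O)C5CC5)c4n3)cc2)CC1`: 50 nM

All three values come from a functional assay on HCC827 cells (Homo sapiens) for antiproliferative activity, read by MTT assay, with a stated time of 72 h; a higher number here means a weaker inhibitor, a lower number a stronger inhibitor. Compound 3 sits second highest of the three numbers: compound 1 gives the higher number, a 7.0-fold lower number from compound 1 to compound 3 (0.85 log units; beyond the scatter), while compound 2 gives the lower one, a 20-fold higher number from compound 2 to compound 3 (1.30 log units; beyond the scatter).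

The next compound is compound 4, `CNC(=O)CN1CC[C@H](n2c(Nc3ccc(F)cc3)nc3cnc(Nc4ccc(N5CCN(C)CC5)cc4)nc32)C1`, not yet measured in this assay. Its change from compound 3 is 1-((methylcarbamoyl)methyl)pyrrolidin-3-yl in place of 2-((cyclopropylsulfonyl)amino)ethyl on an aromatic nitrogen.

Within the data shown here, two measured steps bear on this change. The ring against the open chain is covered by the step from compound 2 to compound 3, a 20-fold higher number from compound 2 to compound 3 (1.30 log units; beyond the scatter), which went against the open chain. The substituent on the pyrrolidine nitrogen is covered by the step from compound 1 to compound 2, a 140-fold lower number from compound 1 to compound 2 (2.15 log units; beyond the scatter), where the cyclopropylsulfonyl gave the far lower number and the (hydroxymethyl)carbonyl the higher one. Compound 4 returns to the pyrrolidine but carries neither group; its (methylcarbamoyl)methyl is closer in kind to the carbonyl-bearing substituent of compound 1 than to the sulfonyl of compound 2. Among the measured compounds shown here, the two steps therefore pull in opposite directions, and no measured pair isolates this new substituent.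

Compound 4 is expected to land near compound 3, estimated at 60 nM with a range of 15 nM to 250 nM, the expected step being a 1.2-fold higher number from compound 3 to compound 4 (0.08 log units; within the scatter) and not clearly beyond the scatter.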

Compound 4, half-maximal inhibitory concentration: 1520 nM
Beside the measured number, compound 4's estimate is 25-fold (1.40 log units) below it, outside the stated range (above it).
By their numbers in this assay, from the lowest: compound 2; then compound 3; then compound 1; then compound 4.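

In this assay, the pyrrolidine on the aromatic nitrogen does not by itself give the lower number: 1-((methylcarbamoyl)methyl)pyrrolidin-3-yl in place of 2-((cyclopropylsulfonyl)amino)ethyl gives a 30-fold higher number from compound 3 to compound 4 (1.48 log units; beyond the scatter), so the advantage of the ring over the open chain seen with the cyclopropylsulfonyl does not carry over to this substituent. The group on the pyrrolidine nitrogen weighs heavily at this position, with a 610-fold higher number from compound 2 to compound 4 (2.78 log units; beyond the scatter) and, against the other non-sulfonyl substituent, a 4.3-fold higher number from compound 1 to compound 4 (0.64 log units; beyond the scatter), which leaves compound 4 as the weakest of the four. No measurement on hand gives a cause for these steps.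

The compounds shown leave open whether the low number of compound 2 depends on the sulfonyl or on the cyclopropyl, a question that a methylsulfonyl or a cyclopropylcarbonyl on the pyrrolidine nitrogen would address. Also open, on these data alone, is how the pyrrolidine with an unsubstituted ring amine, or the open ethyl chain ending in the (methylcarbamoyl)methyl amine, would compare with these four.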